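Lipophilicity notes: isopropoxy replacing dimethylisoxazole in the lactam series

The source may report more compounds than this note shows. Statements on the series, on what has been measured and on what is new or still open speak of the compounds shown alone.

Compound 1 `Cc1cc(C)c(CN2CCc3ccc(-c4c(C)noc4C)c(Cl)c3C2=O)c(=O)[nH]1` gives 2.6 in a physicochemical assay for lipophilicity, at pH 7.4 (on this read-out lower numbers stand for lower lipophilicity and higher numbers for higher lipophilicity), the second highest of three numbers: compound 2 `Cc1cc(C)c(CN2CCc3c(Cl)cc(-c4c(C)noc4C)c(Cl)c3C2=O)c(=O)[nH]1` gives 3.1, compound 3 `COc1cccc(C(=O)NCc2c(C)cc(C)[nH]c2=O)c1O` gives 1.9. Within the data shown here, the one single-point step, a number 0.50 log units higher from compound 1 to compound 2 (beyond the scatter), concerns a different kind of change. Compound 4 `Cc1cc(C)c(CN2CCc3ccc(OC(C)C)c(Cl)c3C2=O)c(=O)[nH]1` differs from compound 1 by isopropoxy in place of 3,5-dimethyl-1,2-oxazol-4-yl on an aromatic carbon. Among the measured compounds shown here, no measured step covers this exchange; the ring that leaves and the chain that enters are both uncharged and of similar acceptor count, so the expectation is a step of a number 0.20 log units higher from compound 1 to compound 4 (within the scatter) in this assay, close to the scatter and of uncertain sign. Compound 4 is therefore estimated at 2.8, within 2.3 to 3.3.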

Compound 4, distribution coefficient: 2.7
Compound 4: the middle estimate sits 0.10 log units above what was measured; the range from low to high includes it.
By their numbers in this assay, from the lowest: compound 3; then compounds 1 and 4 (each within the scatter of the next); then compound 2.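

Isopropoxy in place of 3,5-dimethyl-1,2-oxazol-4-yl on this aromatic carbon, ortho to a chloro group, gives a number 0.10 log units higher from compound 1 to compound 4 (within the scatter) on the read-out of this assay for this pair. At this position, then, a five-membered aromatic ring can give way to an open chain of fewer heavy atoms with no step beyond the scatter, whereas the chloro change gives a number 0.50 log units higher from compound 1 to compound 2 (beyond the scatter) in a separate place on the core. No available evidence explains this result.

Still open, as far as these compounds go, is whether a longer alkoxy chain, an amine or a carboxylic acid at this position would also stay within the scatter of compound 1. Also open, from the compounds shown here alone, is whether isopropoxy behaves alike on the core of compound 2, which carries the second chloro group.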